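The compounds below may be only part of what the source reports. "The series", "measured", "known", "first", "only" and "open" are said of these compounds alone.

In an assay on Sf21 cells for inhibition of ubiquitin carboxyl-terminal hydrolase 7 (Homo sapiens), read by spectrophotometry, with stated times of 30 min and 2 h (a higher number here means a weaker inhibitor, a lower number a stronger inhibitor), compound 3 `O=c1c2cnn(-c3ccc(F)cc3)c2ncn1CC1(O)CCN(Cc2ccc(Br)cc2Cl)CC1` gives 1900 nM, the lowest of the two numbers reported; compound 1 `O=c1c2cnn(-c3ccc(F)cc3)c2ncn1CC1(O)CCN(Cc2ccccc2Cl)CC1` gives 3400 nM, and compound 2 `O=c1c2cnn(-c3ccc(F)cc3)c2ncn1CC1(O)CCN(Cc2c(Cl)cccc2Cl)CC1` gives "not determined" (no result reported), so no number was reported for it. Going by the values given here, the only single-point step among the measured compounds, a 1.8-fold lower number from compound 1 to compound 3 (0.25 log units; within the scatter), stays within the scatter. Compound 4 `COC(=O)c1ccc(CN2CCC(O)(Cn3cnc4c(cnn4-c4ccc(F)cc4)c3=O)CC2)c(Br)c1` differs from compound 3 by 2-bromo-4-(methoxycarbonyl)phenyl in place of 4-bromo-2-chlorophenyl on a saturated chain carbon bound to an amine nitrogen in a ring. Among the compounds with values here, no measured step covers this exchange: the one known step concerns a bromo added to the benzyl ring and left the number essentially unchanged, so it bears on the new change only loosely. A number close to that of compound 3 is therefore expected, with a wide range. Compound 4 is expected to give about 2000 nM, between 700 nM and 6000 nM. The expected step is a 1.1-fold higher number from compound 3 to compound 4 (0.02 log units; within the scatter).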

Compound 4, half-maximal inhibitory concentration: 900 nM
Estimate against measurement, compound 4: 2.2-fold (0.35 log units) above, and the stated range covers the measured number.
By their numbers in this assay, from the lowest: compound 4; then compounds 3 and 1 (each within the scatter of the next).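

In this assay, going by these compounds alone, the exchange of 4-bromo-2-chlorophenyl for 2-bromo-4-(methoxycarbonyl)phenyl gives the first step at this position beyond the scatter (a 2.1-fold lower number from compound 3 to compound 4 (0.32 log units; beyond the scatter)), and the same group in place of 2-chlorophenyl gives a similar modest gain (a 3.8-fold lower number from compound 1 to compound 4 (0.58 log units; beyond the scatter)). The position therefore takes the larger group with its methoxycarbonyl without any loss. Nothing available accounts for the gain.

Because the halogens and the methoxycarbonyl change together, the compounds shown leave open which of them carries the step. On these data alone, whether a carboxylic acid or a primary amide in place of the methoxycarbonyl would move the number further also stays open.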